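Toxicity notes: from compound 2 to the nitrophenyl analogue

The compounds below may be only part of what the source reports. "The series", "measured", "known", "first", "only" and "open" are said of these compounds alone.

For the measured compounds named here, compound 2 `COc1ccccc1N1CCN(CC(=O)N(c2ccccc2)c2ccccc2)CC1` is the only member of the set that returns a number in a toxicity assay on the whole organism (strain albino) for activation, with Mus musculus as the target, with stated times of 30 min and 240 min; a lower number here means that less compound is needed, a higher number that more compound is needed for the effect: compound 2 gives 50.4 mg/kg. Compound 1 `Cc1cccc(N2CCN(CC(=O)N(c3ccccc3)c3ccccc3)CC2)c1C` gives > 40 mg/kg in this assay, which is a limit and not a number. Compound 3 `O=C(CN1CCN(c2ccc(F)cc2)CC1)N(c1ccccc1)c1ccccc1` gives > 40 mg/kg in this assay, again a limit. The set is thus shaped by the limit of > 40 mg/kg in this assay, at which 2 of the 3 values shown sit.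

Three measured steps exist, each changing the aryl group on the ring nitrogen of the shared core: a step that the limit leaves unreadable from compound 1 to compound 2; a step that the two limits leave unreadable from compound 1 to compound 3; a step that the limit leaves unreadable from compound 2 to compound 3. None of them has a readable size, so they show neither a direction nor a magnitude for an aryl exchange at that position.

Compound 4 `O=C(CN1CCN(c2ccc([N+](=O)[O-])cc2)CC1)N(c1ccccc1)c1ccccc1` differs from compound 2 by 4-nitrophenyl in place of 2-methoxyphenyl on an amine nitrogen in a ring. With no readable step in this assay to lean on, the change is taken to leave the dose for half-maximal effect close to that of compound 2, with a real chance that the assay again reports only a limit. Compound 4 is therefore expected at 50 mg/kg, in a range from 25 mg/kg to 100 mg/kg. The step this estimate means, a 1.0-fold lower number from compound 2 to compound 4 (0.00 log units; within the scatter), is expected to lie within the scatter.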

Compound 4, dose for half-maximal effect: > 40 mg/kg
Compound 4 was reported as a limit (the forecaster's own chance of this, stated with the estimate: 45%); the middle value does not contradict the limit.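

Compound 4 gives > 40 mg/kg in this assay, which is a limit and not a number, so its steps to compound 1, compound 2 and compound 3 cannot be read. The compounds shown leave open the direction and size of any effect of exchanging the aryl group on the ring nitrogen, and the set stays shaped by one value: the limit of > 40 mg/kg in this assay, at which 3 of the 4 values shown sit.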